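The source may report more compounds than this note shows. Statements on the series, on what has been measured and on what is new or still open speak of the compounds shown alone.

Compound 1 `O=c1[nH]nc2n(c1=O)CCN2c1ccccc1`: 30%
Compound 2 `COc1ccccc1N1CCn2c1n[nH]c(=O)c2=O`: 17%
Compound 3 `O=c1[nH]nc2n(c1=O)CCN2c1cccc(Cl)c1`: 24%

All three compounds share one core and differ only in what sits on the phenyl ring attached to it. They were examined in an ADME assay on Vero cells (Chlorocebus sabaeus) for cytotoxicity, with a stated time of 72 h, tested at 50 ug/mL; on this read-out higher numbers stand for a stronger effect at the one concentration tested and lower numbers for a weaker effect. Compound 1 carries an unsubstituted phenyl ring and gives the highest of the three numbers, but its margin over compound 3 is a number 6 percentage points lower from compound 1 to compound 3 (within the scatter), which is within the scatter, so the two cannot be told apart. Only compound 2 stands clearly apart, with a number 13 percentage points lower from compound 1 to compound 2 (beyond the scatter).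

Compound 4 `COc1ccc(N2CCn3c2n[nH]c(=O)c3=O)cc1` has not yet been measured in this assay. It differs from compound 1 by methoxy in place of hydrogen on an aromatic carbon. Among the compounds with values here, two measured steps bear on this change. The closest is the step to compound 2, which also adds a methoxy to the phenyl ring, though at a different place, and gives a number 13 percentage points lower from compound 1 to compound 2 (beyond the scatter). The step to compound 3, a chloro in place of hydrogen, gives a number 6 percentage points lower from compound 1 to compound 3 (within the scatter) and stays within the scatter. Both steps point the same way, downward, and neither is large. A small to modest decrease in this assay is therefore expected for compound 4, of about a number 8 percentage points lower from compound 1 to compound 4 (within the scatter). Compound 4 is estimated at 22%, with a range from 10% to 35%.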

Compound 4, a percentage reported as inhibition, at one concentration (the size of the read-out at that concentration, not a potency): 10%
For compound 4 the middle estimate is 12 percentage points above the measured one; the measured number falls inside the stated range.
By their numbers in this assay, from the lowest: compounds 4, 2, 3 and 1 (each within the scatter of the next, the first and the last beyond it).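

With the methoxy para to a large group, the phenyl ring of the shared core gives a number 20 percentage points lower from compound 1 to compound 4 (beyond the scatter) in this assay, so this position also tolerates the change with a lower number, and the step is clear of the usual variation between repeats. The earlier methoxy result, a number 13 percentage points lower from compound 1 to compound 2 (beyond the scatter), came from a different place on the ring, and since compounds 2 and 4 lie within the scatter of each other, these two placements of methoxy cannot be told apart by this read-out, while both stand apart from the unsubstituted compound 1. No measurement available here explains why adding methoxy goes with the lower number.

The compounds shown leave open whether this drop belongs to methoxy itself or would also appear with chloro, an amine, a carboxylic acid or a longer chain such as ethoxy on the same aromatic carbon. Going by these compounds, each number also comes from one concentration only, so how these compounds would compare across a range of concentrations remains open.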